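Tetrazolylacetamide series: aryl in place of pyridinyl on the tetrazole

The source may hold more compounds than are shown below. What is called first, only, known or untested is meant among the compounds shown, and "the series" means these compounds.

Measured compounds in an assay on HEK293 cells for activation of Kir3.1/Kir3.2 (Homo sapiens), read by thallium flux; on this read-out higher numbers stand for larger maximal responses and lower numbers for smaller maximal responses:
compound 1 `CC1(c2cc(NC(=O)Cn3nnc(-c4ccccc4)n3)n(C3CCCCC3)n2)CC1` gives > 10%.
compound 2 `Cc1cc(NC(=O)Cn2nnc(-c3ccccc3)n2)n(Cc2ccccc2)n1` gives 74%.
compound 3 `Cc1cc(NC(=O)Cn2nnc(-c3ccccn3)n2)n(C2CCCCC2)n1` gives 81%.

The result of compound 1 in this assay is a limit of the assay, not a number (the limit of > 10% in this assay, at which 1 of the 3 values shown sits). Among the two numbers, compound 3 gives the higher value with 81%, but compound 2 with 74% lies within the scatter of it, so no order between the two can be claimed.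

Compound 4 `Cc1cc(NC(=O)Cn2nnc(-c3ccc(Cl)c(C)c3)n2)n(C2CCCCC2)n1` is not yet measured. It differs from compound 3 in one place: 4-chloro-3-methylphenyl in place of pyridin-2-yl on an aromatic carbon. Going by the values given here, no measured pair shows this kind of change, so the expected size of the step from compound 3 to compound 4 cannot be read from a measured step. The expectation is a step of a number 6 percentage points lower from compound 3 to compound 4 (within the scatter), that is none beyond the scatter, with a wider range on the lower side. Compound 4 is estimated at 75%, between 45% and 95%.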

Compound 4, largest response reached (Emax), in percent of the reference or control that the assay uses: 89%
The estimate for compound 4 lay 14 percentage points below the measured number; the measured number falls inside the stated range.
By their numbers in this assay, from the lowest: compounds 2, 3 and 4 (each within the scatter of the next, the first and the last beyond it).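

In this assay the swap on the aromatic carbon of the five-membered ring gives a number 8 percentage points higher from compound 3 to compound 4 (within the scatter), so this position accepts 4-chloro-3-methylphenyl as well as pyridin-2-yl, with no difference that can be claimed. The ring nitrogen of pyridin-2-yl and its hydrogen-bond acceptor are therefore not needed for a large maximal response in this pair. The data shown give no reason for this outcome.

Going by these compounds, it remains open whether the chlorine or the methyl alone would give the same response. Also open, on these data alone, is how an amine or a carboxylic acid on this aryl ring would read out.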